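Dropping the chloro from compound 2

This account rests on a few compounds, and the source may have more. Where it says the series, first, only, none or still open, it means among the compounds named here.

Of the compounds shown here, two have numbers so far in a functional assay on HepG2 cells (Homo sapiens) for antiproliferative activity, read by MTT assay, with a stated time of 48 h; on this read-out lower numbers stand for stronger inhibition and higher numbers for weaker inhibition. Compound 1 (`O=C(NO)c1ccc(/C=C/c2ccc(O)cc2)o1`) gives 20900 nM. Compound 2 (`O=C(/C=C/c1ccc(/C=C/C(=O)c2cccc(Cl)c2)o1)NO`) gives 54500 nM, the higher of the two numbers, and its gap to compound 1 lies beyond the scatter. Compound 3 (`O=C(/C=C/c1ccc(/C=C/C(=O)c2ccccc2)o1)NO`) has no reading yet. It differs from compound 2 by hydrogen in place of chloro on an aromatic carbon, so that 3-chlorophenyl becomes phenyl. Among the measured compounds shown here, no measured pair isolates this change, so the expectation rests on the value of compound 2 at 54500 nM and on the small size of the edit. In this assay, no step beyond the scatter is expected, with a slight lean towards a lower number. The estimated change is a 1.2-fold lower number from compound 2 to compound 3 (0.08 log units; within the scatter). For compound 3 the expected value is 45000 nM, with an estimated range of 18000 nM to 110000 nM.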

Compound 3, half-maximal inhibitory concentration: 12100 nM
Estimate against measurement, compound 3: 3.7-fold (0.57 log units) above; measured number below the stated range.
By their numbers in this assay, from the lowest: compounds 3 and 1 (each within the scatter of the next); then compound 2.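

In this assay, among the compounds shown here, the change from 3-chlorophenyl to phenyl gives a 4.5-fold lower number from compound 2 to compound 3 (0.65 log units; beyond the scatter) and is the first single-place comparison. It shows that this position, on the six-membered aromatic ring and meta to a large group, is not silent: one chloro, a single heavy atom, separates the two compounds by more than the scatter, and the compound with hydrogen there has the lower number. Nothing at hand bears on the reason for this step, so it stands as an observation only.

A single pair cannot show whether the step is specific to chloro or would also appear with another group at the same place, such as fluoro, methyl or methoxy. Also open, from the compounds shown here alone, are whether chloro elsewhere on the ring gives a similar step and whether the same change behaves alike with the hydroxamic acid side of the molecule altered, for example with a carboxylic acid in its place.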